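The compounds below may be only part of what the source reports. "The series", "measured", "known", "first", "only" and "open" are said of these compounds alone.

Compound 2 `COc1ccc(C(=O)OC(CCN(C)C)c2ccc(Cl)cc2)cc1` gives 2190 nM in an assay on NIH3T3 cells with Urotensin-2 receptor (Homo sapiens) as the target; a higher number here means that more compound is needed for the effect, a lower number that less compound is needed. Compound 1 `Cc1ccccc1C(=O)OC(CCN(C)C)c1ccc(Cl)cc1` gives 1700 nM in this assay, and the two lie within the scatter of each other, as the step of a 1.3-fold higher number from compound 1 to compound 2 (0.11 log units; within the scatter) shows. Compound 3 `CN(C)CCC(OC(=O)c1ccc(-c2ccccc2)cc1)c1ccc(Cl)cc1` differs from compound 2 by phenyl in place of methoxy on an aromatic carbon. Going by the values given here, no measured step swaps a methoxy for a phenyl; the only measured step, a change of a different group on a carbonyl carbon, stayed within the scatter, so no step beyond the scatter is expected, a 1.1-fold lower number from compound 2 to compound 3 (0.04 log units; within the scatter). Compound 3 is therefore estimated at 2000 nM, between 600 nM and 7000 nM.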

Compound 3, half-maximal effective concentration: 525 nM
Compound 3: middle estimate off by 3.8-fold (0.58 log units), on the high side, outside the stated range (below it).
By their numbers in this assay, from the lowest: compound 3; then compounds 1 and 2 (each within the scatter of the next).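

Replacing methoxy with phenyl on this aromatic carbon, para to a large group, gives a 4.2-fold lower number from compound 2 to compound 3 (0.62 log units; beyond the scatter) in this assay. This is the first change shown that goes beyond the scatter, so what sits at this position can shift the amount of compound needed, and here the group that enters brings an extra aromatic ring. Nothing measured here accounts for the shift.

From the compounds shown here alone, it remains open whether the aromatic ring itself matters, which a cyclohexyl group at this position could test. Going by these compounds, whether an amine or a carboxylic acid there would give a similar number also stays open.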